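The source may report more compounds than this note shows. Statements on the series, on what has been measured and on what is new or still open speak of the compounds shown alone.

Three compounds have been measured in a functional assay on HepG2 cells (Homo sapiens) for inhibition, read by sulforhodamine B assay, with a stated time of 72 h; on this read-out higher numbers stand for weaker inhibition and lower numbers for stronger inhibition:

Compound 1 `C[C@H](Nc1ncnc2[nH]cnc12)c1nn(-c2cccnc2)c2cc(F)ccc12` gives 37500 nM.
Compound 2 `C[C@H](Nc1ncnc2[nH]cnc12)c1nn(-c2ccncc2)c2cc(F)ccc12` gives 23100 nM.
Compound 3 `C[C@H](Nc1ncnc2[nH]cnc12)c1nn(-c2cccc(S(C)(=O)=O)c2)c2cc(F)ccc12` gives 14800 nM.

Among these three, compound 3 has the lowest number. One step is a 1.6-fold lower number from compound 2 to compound 3 (0.19 log units; within the scatter), which is within the scatter, so the two cannot be placed in order. Another step is a 2.5-fold lower number from compound 1 to compound 3 (0.40 log units; beyond the scatter), a modest step beyond the scatter. The other measured step, a 1.6-fold lower number from compound 1 to compound 2 (0.21 log units; within the scatter), also lies within the scatter.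

Compound 4 `C[C@H](Nc1nc(N)nc(N)c1C#N)c1nn(-c2cccc(S(C)(=O)=O)c2)c2cc(F)ccc12` differs from compound 3 at the amine nitrogen whose other neighbours are a saturated chain carbon: a group of 10 heavy atoms (5 carbon, 5 nitrogen; one six-membered aromatic ring with 2 hetero atoms) in place of a group of 9 heavy atoms (5 carbon, 4 nitrogen; one five-membered aromatic ring with 2 hetero atoms, one six-membered aromatic ring with 2 hetero atoms), on an amine nitrogen.

For the measured compounds named here, none of the measured steps bears on this change. All three steps vary the group on the aromatic nitrogen, while the group on the amine nitrogen is the same in compounds 1, 2 and 3. The data therefore give no direction for this assay, and the reasonable expectation is a step of no definite size in either direction, with a wide range around the value of compound 3. The expected step is a 1.0-fold higher number from compound 3 to compound 4 (0.01 log units; within the scatter). Compound 4 is thus estimated at 15000 nM, with a range from 3000 nM to 60000 nM.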

Compound 4, half-maximal inhibitory concentration: 19100 nM
Beside the measured number, compound 4's estimate is 1.3-fold (0.10 log units) below it; low and high end bracket the measured number.
By their numbers in this assay, from the lowest: compounds 3, 4, 2 and 1 (each within the scatter of the next, the first and the last beyond it).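

Compounds 1, 2 and 3 all carry the same group on the amine nitrogen, so compound 4 gives the first view of this position in this assay. With 3-(methylsulfonyl)phenyl held on the aromatic nitrogen, putting 2,6-diamino-5-cyanopyrimidin-4-yl on the amine nitrogen in place of the group with the fused five- and six-membered aromatic rings gives a 1.3-fold higher number from compound 3 to compound 4 (0.11 log units; within the scatter) and so leaves the two compounds impossible to place in order, which shows that a single six-membered aromatic ring bearing a nitrile and two amino groups can stand at this position with no step beyond the scatter. Nothing available explains this outcome, and no measurement bears on how either group acts at this position.

The compounds shown leave open whether this result holds with pyridin-3-yl or pyridin-4-yl on the aromatic nitrogen, since the new group is seen only with 3-(methylsulfonyl)phenyl. They also leave open which part of the new group matters, as a plain pyrimidin-4-yl without the nitrile and amino groups, or a carboxylic acid in place of the nitrile, does not appear among them.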